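Phenylurea substituent change on the shared core: methyl to fluoro

This account rests on a few compounds, and the source may have more. Where it says the series, first, only, none or still open, it means among the compounds named here.

Measured so far:
compound 1 `O=C(Nc1ccccc1)Nc1nnc(Sc2ncnc3scc(-c4ccncc4)c23)s1` — 5700 nM
compound 2 `Cc1ccc(NC(=O)Nc2nnc(Sc3ncnc4scc(-c5ccncc5)c34)s2)cc1` — 2100 nM

Both compounds were tested in a functional assay on PC-3 cells (Homo sapiens) for antiproliferative activity, read by MTT assay, with a stated time of 48 h; a lower number here means a stronger inhibitor, a higher number a weaker inhibitor. Compound 2 gives the lowest of the two numbers, the nearest being compound 1, which differs by a methyl in place of hydrogen on an aromatic carbon; that step was a 2.7-fold lower number from compound 1 to compound 2 (0.43 log units; beyond the scatter).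

Compound 3 `O=C(Nc1ccc(F)cc1)Nc1nnc(Sc2ncnc3scc(-c4ccncc4)c23)s1` is not yet measured. Relative to compound 2 the change is fluoro in place of methyl on an aromatic carbon, at an aromatic carbon of a six-membered aromatic ring of carbon only, para to a large group.

For the measured compounds named here, only the step from compound 1 to compound 2 bears on this, and it concerns the same position. Fluoro is neither hydrogen nor methyl, so compound 3 is expected to land between compound 1 and compound 2 in this assay, that is a 1.7-fold higher number from compound 2 to compound 3 (0.22 log units; within the scatter), a small loss that may not exceed the scatter. The estimate for compound 3 is 3500 nM, with a range from 1500 nM to 8000 nM.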

Compound 3, half-maximal inhibitory concentration: 970 nM
Beside the measured number, compound 3's estimate is 3.6-fold (0.56 log units) above it; the whole stated range lies above it.
By their numbers in this assay, from the lowest: compound 3; then compound 2; then compound 1.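

In this assay, fluoro in place of methyl gives a 2.2-fold lower number from compound 2 to compound 3 (0.34 log units; beyond the scatter), so the methyl group does not set the lowest number at this aromatic carbon, para to a large group. Fluoro in place of hydrogen gives a 5.9-fold lower number from compound 1 to compound 3 (0.77 log units; beyond the scatter), so both substituents shown here lower the number relative to hydrogen, and the order at this position runs from 4-fluorophenyl through 4-methylphenyl to the unsubstituted phenyl. Nothing available explains why fluoro gives the lower number of the two substituents.

From the compounds shown here alone, with only hydrogen, methyl and fluoro at this one position, it remains open whether chloro, methoxy or trifluoromethyl would continue this order. Going by these compounds, it also remains open whether fluoro on another carbon of the same ring would give a similar step.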